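A few compounds are considered here, and "the series" means these few. Any claim that something is new, unique, unknown or untested is made for them only; others in the source may bear on it.

Working notes on the series.

Compound 1, `COc1cc(-c2nn(-c3cccc(NC(=O)Nc4ccc(Cl)c(Cl)c4)c3)cc2-c2ccncc2)ccc1Cl`, is read in a functional assay on HCT-116 cells (Homo sapiens) for inhibition, read by sulforhodamine B assay, with a stated time of 48 h (on this read-out higher numbers stand for lower toxicity in this test and lower numbers for higher toxicity in this test), only as a limit: compound 1 gives > 50000 nM. Compound 2, `O=C(Nc1cccc(-n2cc(-c3ccncc3)c(-c3ccc(Cl)c(O)c3)n2)c1)Nc1ccc(Cl)c(Cl)c1`, is likewise only a limit; in this assay compound 2 gives > 32500 nM. Among the measured compounds shown here, the one measured step between neighbours, a step that the two limits leave unreadable from compound 1 to compound 2, is therefore not readable, both ends sitting at a limit (the limit of > 50000 nM in this assay, at which 1 of the 3 values shown sits, (the limit of > 32500 nM in this assay, at which 1 of the 3 values shown sits)). For the measured compounds named here, compound 3, `O=C(Nc1cccc(-n2cc(-c3ccncc3)c(-c3ccc(Cl)c(O)c3)n2)c1)Nc1cc(C(F)(F)F)cc(C(F)(F)F)c1`, carries the bis(trifluoromethyl)phenyl urea on the phenol core and is the only compound of the three with a number: in this assay compound 3 gives 2650 nM. Compound 2 and compound 3 are not a single-place pair, so their values are only noted side by side, not read as a step.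

Compound 4, `COc1cc(-c2nn(-c3cccc(NC(=O)Nc4ccc(Cl)c(C(F)(F)F)c4)c3)cc2-c2ccncc2)ccc1Cl`, differs from compound 1 by trifluoromethyl in place of chloro on an aromatic carbon. Going by the values given here, no measured step covers this change; the measured step from compound 1 to compound 2 sits elsewhere and is unreadable. Among the compounds with values here, the only guide is that the sole numbered compound, compound 3, carries trifluoromethyl on the urea aryl. The expectation for compound 4 in this assay is a modest move toward higher toxicity, an at least 2.5-fold lower number from compound 1 to compound 4 (0.39 log units; beyond the scatter), with a fair chance of another limit; compound 4 is estimated at 20000 nM, range 4000 nM to 60000 nM.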

Compound 4, concentration lethal to 50% of the cells: 21500 nM
Estimate against measurement, compound 4: 1.1-fold (0.03 log units) below; measured number inside the range.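

Among the compounds shown here, replacing 3,4-dichlorophenyl with 4-chloro-3-(trifluoromethyl)phenyl while keeping the core of compound 1 gives the first readable step in this assay, an at least 2.3-fold lower number from compound 1 to compound 4 (0.36 log units; beyond the scatter). For the compounds shown here, until now, the only number belonged to compound 3, which could not be tied to any single change, whereas this result shows that trifluoromethyl in place of chloro at this one position on the urea aryl is enough on its own to bring a compound of this series to a measurable value. The size of the step is only a lower bound, because compound 1 stands as a limit and not as a number: the limit of > 50000 nM in this assay, at which 1 of the 4 values shown sits.

On these data alone, it remains open whether the same change on the core of compound 2, which is also only a limit, would give a step of similar size, and how much of the number of compound 3 comes from its urea aryl rather than from its core. The compounds shown also leave open how a nitrile, a methyl or an amine at this position would read in this assay.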